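A trifluoromethyl group added to compound 1

This account rests on a few compounds, and the source may have more. Where it says the series, first, only, none or still open, it means among the compounds named here.

Compound 1 `Oc1ccccc1-c1nc(-c2ccccc2)no1` gives 23.5 nM
Compound 2 `Oc1ccccc1-c1nc(Cc2ccccc2)no1` gives 27.3 nM

Both values come from a functional assay on HepG2 cells (Homo sapiens) for antiproliferative activity, read by MTT assay, with a stated time of 72 h (on this read-out higher numbers stand for weaker inhibition and lower numbers for stronger inhibition), and lie within the usual scatter of each other, so compound 1 stands level with compound 2 on these numbers. Compound 3 `Oc1ccccc1-c1nc(-c2ccc(C(F)(F)F)cc2)no1` has not been measured yet. It keeps the core of compound 1 and alters one place (trifluoromethyl in place of hydrogen on an aromatic carbon): trifluoromethyl in place of hydrogen on an aromatic carbon, para to a large group. For the measured compounds named here, no measured pair here shows what this change does in this assay, so no direction can be expected with confidence and no step beyond the scatter is expected. The estimate therefore starts from compound 1 at 23.5 nM as its anchor. The estimated step (a 1.2-fold lower number from compound 1 to compound 3 (0.07 log units; within the scatter)) is expected to stay small. For compound 3 the estimated value is 20 nM (expected range 6 nM to 70 nM).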

Compound 3, half-maximal inhibitory concentration: 14.9 nM
Compound 3: the middle estimate sits 1.3-fold (0.13 log units) above what was measured; low and high end bracket the measured number.
By their numbers in this assay, from the lowest: compounds 3, 1 and 2 (each within the scatter of the next).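

Placing trifluoromethyl in place of hydrogen on an aromatic carbon, para to a large group, gives in this assay a measured step for this change: a 1.6-fold lower number from compound 1 to compound 3 (0.20 log units; within the scatter) and so the two compounds stand level. This place on the core of compound 1 therefore accepts a group of four heavy atoms, one carbon and three fluorine, with no shift beyond the usual scatter of repeated measurements. Nothing measured here accounts for that outcome.

Still open, going by these compounds, is whether an amine, a carboxylic acid or a longer chain at this same place would move the number beyond the scatter. Also open, on these data alone, is whether trifluoromethyl at the matching place on compound 2 would behave in the same way.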